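The source may report more compounds than this note shows. Statements on the series, on what has been measured and on what is new or still open speak of the compounds shown alone.

Measured in a functional assay on MDA-MB-453 cells (Homo sapiens) for antiproliferative activity, read by MTT assay, with a stated time of 72 h; a lower number here means a stronger inhibitor, a higher number a weaker inhibitor:

Compound 1 `O=c1oc2cc(O)ccc2cc1-c1ccc(O)cc1`: > 100000 nM
Compound 2 `Cc1cc(O)ccc1-c1c(C)c2ccc(O)cc2oc1=O`: 55300 nM

The entry for compound 1 is a limit of the assay and not a number. Going by the values given here, compound 2, at 55300 nM, therefore holds the only true number in this assay, and the series offers no measured step between two compounds that differ in one place.

The next compound to be tested is compound 3 `Cc1c(-c2ccc(O)cc2Cl)c(=O)oc2cc(O)ccc12`. It carries chloro in place of methyl on an aromatic carbon, ortho to a large group and meta to a hydroxy group: chloro in place of methyl on an aromatic carbon. Among the compounds with values here, with no measured step to lean on, the expectation rests on the small size of this swap and on the value of compound 2, 55300 nM. Only a small change in this assay is expected, perhaps slightly towards stronger inhibition and little beyond the usual scatter. The expected step is a 1.4-fold lower number from compound 2 to compound 3 (0.14 log units; within the scatter). For compound 3 the estimated value is 40000 nM, with an expected range of 15000 nM to 100000 nM.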

Compound 3, half-maximal inhibitory concentration: 26700 nM
The estimate for compound 3 lay 1.5-fold (0.18 log units) above the measured number; measured number inside the range.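

Chloro in place of methyl at this position, ortho to a large group and meta to a hydroxy group, gives the series its first readable step in this assay: a 2.1-fold lower number from compound 2 to compound 3 (0.32 log units; beyond the scatter). The earlier compounds shown here offered no such pair, and this one shows that the number responds to a change at this position, though only modestly, and that a single heavy atom swapped here is enough to move it. Compound 1 stands at a limit of the assay and not a number, it differs from compound 2 in more than one place, and no step to it can be read: the limit of > 100000 nM in this assay, at which 1 of the 3 values shown sits.

The compounds shown leave open whether this modest gain belongs to chloro in particular or would also appear with another group at this position, such as fluoro, methoxy or an amine. Going by these compounds alone, they also leave open what the other methyl, shared by compound 2 and compound 3 and absent from compound 1, contributes on its own, as no pair here changes that group alone.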